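The compounds below may be only part of what the source reports. "The series", "measured", "known", "first", "only" and "open" are said of these compounds alone.

The account begins with compound 1, `O=C(NCCCCn1cccn1)c1cccc(C2SCC(=O)N2c2cccnc2)c1`, which carries a pyridin-3-yl group on the amide-type nitrogen of its five-membered ring. In a functional assay on HOS-TE85 cells (Homo sapiens) for inhibition, read by CCK-8 assay, with a stated time of 72 h (a lower number here means a stronger inhibitor, a higher number a weaker inhibitor), compound 1 returns only the limit > 1000 nM, not a number. The same is true of compound 2, `COc1ccc(OC)c(N2C(=O)CSC2c2cccc(C(=O)NCCCCc3ccccc3)c2)c1`, which in this assay also reaches only the limit > 1000 nM. Compound 3, `O=C(NCCCCc1ccccc1)c1cccc(C2SCC(=O)N2c2ccc(C3CC3)cc2)c1`, differs from compound 2 only at that ring nitrogen, and in this assay compound 3 gives 217 nM. The step between them is an at least 4.6-fold lower number from compound 2 to compound 3 (0.66 log units; beyond the scatter), and it rests on the limit of > 1000 nM in this assay, at which 2 of the 3 values shown sit, for its lower bound. Compound 1 thus stands among the weaker entries, at the limit where most of the measured values sit.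

Compound 4, `O=C(NCCCCn1cccn1)c1cccc(C2SCC(=O)N2c2cc(Cl)ccn2)c1`, is compound 1 with a single alteration: 4-chloropyridin-2-yl in place of pyridin-3-yl on an amide-type nitrogen in a ring. Within the data shown here, the only measured step at this position is the one from compound 2 to compound 3, and it shows that the group on this ring nitrogen can move the readout beyond the scatter; it does not, however, involve either of the two groups exchanged here. The step from compound 1 to compound 4 is therefore expected to be small and uncertain, a step that the limit leaves unreadable from compound 1 to compound 4, with compound 4 estimated at 1500 nM in this assay, within a range from 300 nM to 6000 nM, and a real chance that only the limit is reported again.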

Compound 4, half-maximal inhibitory concentration: 36.4 nM
Beside the measured number, compound 4's estimate is 41-fold (1.61 log units) above it; the whole stated range lies above it.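

The earlier compounds had shown a readable change on this amide-type nitrogen only between two substituted phenyl groups, 2,5-dimethoxyphenyl and 4-cyclopropylphenyl. Here, one pyridine-type group replaces another, and the exchange of pyridin-3-yl for 4-chloropyridin-2-yl gives an at least 27-fold lower number from compound 1 to compound 4 (1.43 log units; beyond the scatter), so a large step is possible at this position even though each group is one six-membered aromatic ring with 1 hetero atom and the count of hydrogen-bond donors and acceptors stays the same. In this assay, compound 1 gives only a limit, so the full size of this step cannot be read: the limit of > 1000 nM in this assay, at which 2 of the 4 values shown sit.

The exchange adds a chlorine and also changes how the pyridine ring is attached, and the compounds shown do not separate these two changes. Going by these compounds, it remains open where pyridin-2-yl without the chlorine would fall, or the same ring with a bromine or a methyl group in its place, and whether the step would hold with the phenylbutyl chain of compound 3 in place of the pyrazolylbutyl chain of compound 4.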